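A silicon-bearing group in place of pyrrolidin-1-yl

This account rests on a few compounds, and the source may have more. Where it says the series, first, only, none or still open, it means among the compounds named here.

compound 1 `CC(C)=CCC[C@]1(C)/C=C/[C@@H](OC(=O)C=C(C)C)[C@](C)(O)/C=C/C(=O)/C(CCl)=C\C1`: 160 nM
compound 2 `CC(C)=CCC[C@]1(C)/C=C/[C@@H](OC(=O)C=C(C)C)[C@](C)(O)/C=C/C(=O)/C(CN2CCCC2)=C\C1`: 160 nM

Both values come from a functional assay on HL-60 cells (Homo sapiens) for antiproliferative activity, read by MTT assay, with a stated time of 48 h (a lower number here means a stronger inhibitor, a higher number a weaker inhibitor), where compound 2 stands level with compound 1. For the measured compounds named here, only one measured step bears on the site that changes next, a saturated chain carbon bound to a double-bonded ring carbon. Exchanging chloro for pyrrolidin-1-yl there gave no change at the digits printed from compound 1 to compound 2 (within the scatter).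

Compound 3 `CC(C)=CCC[C@]1(C)/C=C/[C@@H](OC(=O)C=C(C)C)[C@](C)(O)/C=C/C(=O)/C(C[Si](C)(C)C(C)(C)C)=C\C1` keeps the shared core and changes the same site again: a group of 7 heavy atoms (6 carbon, 1 silicon; no ring) in place of a group of 5 heavy atoms (4 carbon, 1 nitrogen; one five-membered non-aromatic ring with 1 hetero atom), on a saturated chain carbon bound to a double-bonded ring carbon. Going by the values given here, neither measured compound carries silicon at this site, so the incoming group has no direct precedent in these data. A single step is also thin evidence for how tolerant the site is.

Among the compounds with values here, since the one measured step shows no change at the digits printed from compound 1 to compound 2 (within the scatter), no step beyond the scatter is expected in this assay, and no firm direction can be given. The expected step is a 1.3-fold higher number from compound 2 to compound 3 (0.10 log units; within the scatter). The estimated value for compound 3 is 200 nM, with an expected range from 70 nM to 600 nM.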

Compound 3, half-maximal inhibitory concentration: 2770 nM
The estimate for compound 3 lay 14-fold (1.14 log units) below the measured number; the measured number lies above the stated range.
By their numbers in this assay, from the lowest: compounds 1 and 2 (each within the scatter of the next); then compound 3.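

The site on a saturated chain carbon bound to a double-bonded ring carbon is not indifferent to the group it carries: in this assay, the silicon-bearing group gave a 17-fold higher number from compound 2 to compound 3 (1.24 log units; beyond the scatter), and measured against the chloro compound the result was a 17-fold higher number from compound 1 to compound 3 (1.24 log units; beyond the scatter). The tolerance suggested by the level pair of compound 1 and compound 2 therefore has a limit, and among these three compounds only the group of 7 heavy atoms (6 carbon, 1 silicon; no ring) crosses it. Nothing available here explains why this group behaves differently from chloro and pyrrolidin-1-yl.

The three compounds cannot separate the part played by silicon from that of the group's overall make-up, since a direct comparison would need an all-carbon group such as 2,3,3-trimethylbutan-2-yl or a trimethylsilyl group at the same site. They also leave open how far the level seen with chloro and pyrrolidin-1-yl extends to other groups, such as an open-chain amine like dimethylamino, a morpholine ring or a hydroxyl group.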